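The source may hold more compounds than are shown below. What is called first, only, known or untested is meant among the compounds shown, and "the series" means these compounds.

Measured compounds:
compound 1 `COc1ccc(CNc2nc(SC)nc3ncccc23)cc1` — > 100000 nM
compound 2 `C[Se]c1nc([Se]C)c2cccnc2n1` — "not determined" (no result reported)
compound 3 `[SeH]c1nc(NCc2ccccc2)c2ccccc2n1` — > 100000 nM

In a functional assay on MCF7 cells (Homo sapiens) for cytotoxicity, read by MTT assay, with a stated time of 72 h (on this read-out higher numbers stand for lower toxicity in this test and lower numbers for higher toxicity in this test), compound 1 gives only a limit, > 100000 nM, not a number. Compound 3 likewise reaches only a limit, > 100000 nM, in this assay. For compound 2 no result is reported in this assay, "not determined" (no result reported). Two of the three entries therefore sit at the same limit, (the limit of > 100000 nM in this assay, at which 2 of the 3 values shown sit). Compound 4 `CSc1nc(NCc2ccccc2)c2cccnc2n1` has not been measured; it differs from compound 1 in one place: hydrogen in place of methoxy on an aromatic carbon. Among the compounds with values here, no step between measured compounds is available, so the size of this change cannot be read from the data. The expected step from compound 1 to compound 4, a number no higher from compound 1 to compound 4 (the limit leaves the size open), is none beyond the scatter. Compound 4 is estimated at 100000 nM, within 30000 nM to 300000 nM, most likely again a limit.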

Compound 4, concentration lethal to 50% of the cells: > 100000 nM
Compound 4: only a limit was reported; the forecaster's own chance of this, stated with the estimate: 80%; the middle value sits exactly at the limit.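

Within the data shown here, compound 1 and compound 4 both reach only a limit, so no step between them can be read: the limit of > 100000 nM in this assay, at which 3 of the 4 values shown sit. The compounds shown leave open how far hydrogen in place of methoxy moves the value, and what number any of these compounds would give.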